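The source may report more compounds than this note shows. Statements on the series, on what has been measured and on what is new or still open speak of the compounds shown alone.

For the measured compounds named here, compound 1 `COc1ccc2c(OCc3nnc4sc(-c5cc[nH]c5)nn34)ccnc2c1` gives 353 nM in a functional assay on EBC-1 cells (Homo sapiens) for antiproliferative activity, with a stated time of 72 h (a lower number here means a stronger inhibitor, a higher number a weaker inhibitor), the highest of the three numbers measured so far. Compound 2 `COc1ccc2[nH]c(-c3nn4c(COc5ccnc6cc(OC)ccc56)nnc4s3)cc2c1` gives 85.6 nM in this assay, and compound 3 `COc1ccc(-c2nn3c(COc4ccnc5cc(OC)ccc45)nnc3s2)cc1` gives 161 nM. Compound 4 `COc1cccc(-c2nn3c(COc4ccnc5cc(OC)ccc45)nnc3s2)c1` has not yet been measured; it differs from compound 1 in one place: 3-methoxyphenyl in place of 1H-pyrrol-3-yl on an aromatic carbon. Going by the values given here, two measured steps bear on this change. Putting 5-methoxy-1H-indol-2-yl in that place gave a 4.1-fold lower number from compound 1 to compound 2 (0.62 log units; beyond the scatter), and putting 4-methoxyphenyl there gave a 2.2-fold lower number from compound 1 to compound 3 (0.34 log units; beyond the scatter). Both replacements lowered the number, so a modest lowering is expected for 3-methoxyphenyl as well, closest to what compound 3 showed at 161 nM. Compound 4 is therefore estimated at 180 nM, with a range from 80 nM to 400 nM. That corresponds to an expected 2.0-fold lower number from compound 1 to compound 4 (0.29 log units; within the scatter).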

Compound 4, half-maximal inhibitory concentration: 472 nM
For compound 4 the middle estimate is 2.6-fold (0.42 log units) below the measured one; the measured number lies above the stated range.
By their numbers in this assay, from the lowest: compounds 2 and 3 (each within the scatter of the next); then compounds 1 and 4 (each within the scatter of the next).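

In this assay, 3-methoxyphenyl in place of 4-methoxyphenyl gives a 2.9-fold higher number from compound 3 to compound 4 (0.47 log units; beyond the scatter) and so the two methoxyphenyl groups are not interchangeable at this position. 3-methoxyphenyl in place of 1H-pyrrol-3-yl gives a 1.3-fold higher number from compound 1 to compound 4 (0.13 log units; within the scatter) and in place of 5-methoxy-1H-indol-2-yl gives a 5.5-fold higher number from compound 2 to compound 4 (0.74 log units; beyond the scatter) and so, unlike compounds 2 and 3, compound 4 brings no gain over compound 1. No available measurement accounts for the difference between the two methoxyphenyl groups. On these data alone, it remains open whether an amine or a carboxylic acid in place of the methoxy group would show the same difference.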